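Stereoisomeric cyclohexanediol glycosides: cytotoxicity at the assay limit

A few compounds are considered here, and "the series" means these few. Any claim that something is new, unique, unknown or untested is made for them only; others in the source may bear on it.

Compound 1 `O=C(/C=C\c1ccc(O)cc1)O[C@H]1[C@H](O[C@@H]2CCCC[C@H]2O)O[C@H](CO)[C@@H](O)[C@@H]1O`, compound 2 `O=C(OC[C@H]1O[C@@H](O[C@@H]2CCCC[C@H]2O)[C@H](O)[C@@H](O)[C@@H]1O)c1ccc(O)cc1` and compound 3 `O=C(/C=C/c1ccc(O)cc1)O[C@H]1[C@H](O[C@H]2CCCC[C@@H]2O)O[C@H](CO)[C@@H](O)[C@@H]1O` have all been run in a functional assay on SK-MEL-2 cells (Homo sapiens) for cytotoxicity, read by sulforhodamine B assay; a higher number here means a weaker inhibitor, a lower number a stronger inhibitor. In this assay compound 1 gives only a limit, > 10000 nM. Compound 2 likewise gives only a limit, > 10000 nM. Going by the values given here, compound 3 stands where the others do, at a limit of > 10000 nM, with no number inside the range of the assay; this is the state of the whole series so far, (the limit of > 10000 nM in this assay, at which 3 of the 3 values shown sit).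

Among the compounds with values here, the one step between measured compounds, a step that the two limits leave unreadable from compound 1 to compound 3, cannot be read because the limit of > 10000 nM in this assay, at which 3 of the 3 values shown sit, both ends sit at the limit, although the two differ only in configuration, (the fact that compounds 1 and 3 differ only in the configuration as drawn).

Compound 4 `O=C(/C=C/c1ccc(O)cc1)O[C@H]1[C@H](O[C@@H]2CCCC[C@@H]2O)O[C@H](CO)[C@@H](O)[C@@H]1O` follows from compound 3 by the two compounds have the same atoms and bonds and differ only in configuration as drawn: 1 of 8 stereo elements differ; a stereocentre at a saturated ring carbon is drawn S in compound 3 and R in compound 4. Within the data shown here, no measured step bears on this change with a readable size. With compound 3 at a limit and compound 1 at a limit across a larger change of configuration, compound 4 is expected to remain at the limit as well. The step from compound 3 to compound 4 is therefore expected to be about a step that the limit leaves unreadable from compound 3 to compound 4, none beyond the scatter. Compound 4 is estimated at 15000 nM, in a range from 7000 nM to 40000 nM.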

Compound 4, half-maximal inhibitory concentration: > 10000 nM
Compound 4 ended at the assay's limit (the forecaster's own chance of this, stated with the estimate: 85%); the middle value lies beyond the limit too.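

No new step can be read for compound 1, compound 3 or compound 4, since all three rest at the same limit rather than at a number: the limit of > 10000 nM in this assay, at which 4 of the 4 values shown sit.

The compounds shown leave open whether any configuration or other change on the shared core gives a measurable value in this assay.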